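From Methyl to 4-Chlorophenyl: Expecting a Weaker Effect

A few compounds are considered here, and "the series" means these few. Any claim that something is new, unique, unknown or untested is made for them only; others in the source may bear on it.

Of the compounds shown here, three sharing one core have been tested in a functional assay on MCF7 cells (Homo sapiens) for antiproliferative activity, read by MTT assay, with a stated time of 48 h, tested at 25 uM; a lower number here means a stronger effect, a higher number a weaker effect of the compound at the concentration tested. Compound 1 `OC(CCn1nc2c(Br)c(Br)c(Br)c(Br)c2n1)c1cccc(Cl)c1` gives 101%, and compound 2 `OC(CCn1nc2c(Br)c(Br)c(Br)c(Br)c2n1)c1ccc(Br)cc1` gives 105%. Compound 3 `CC(O)CCn1nc2c(Br)c(Br)c(Br)c(Br)c2n1`, which carries a methyl where the other two carry an aromatic ring, gives 73%, the lowest number of the three and so the strongest effect seen here.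

Compound 4 `OC(CCn1nc2c(Br)c(Br)c(Br)c(Br)c2n1)c1ccc(Cl)cc1` has not yet been measured. Its change from compound 3 is 4-chlorophenyl in place of methyl on a saturated chain carbon bound to an oxygen on a saturated carbon and a saturated chain carbon. Among the measured compounds shown here, two measured steps bear on this change: a number 28 percentage points lower from compound 1 to compound 3 (beyond the scatter) and a number 32 percentage points lower from compound 2 to compound 3 (beyond the scatter). Both show that exchanging an aromatic ring for methyl lowers the number by a similar amount, and a number 4 percentage points higher from compound 1 to compound 2 (within the scatter) shows that the two rings themselves give nearly the same number. Going the other way, from methyl to a ring, the number should therefore rise by roughly that same amount, back toward the values of compound 1 and compound 2. The step expected is a number 29 percentage points higher from compound 3 to compound 4 (beyond the scatter). Compound 4 is estimated at 102%, within a range from 90% to 114%.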

Compound 4, a percentage reported as activity, at one concentration (the size of the read-out at that concentration, not a potency): 92%
For compound 4 the middle estimate is 10 percentage points above the measured one; the measured number falls inside the stated range.
By their numbers in this assay, from the lowest: compound 3; then compounds 4, 1 and 2 (each within the scatter of the next, the first and the last beyond it).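

Among the compounds shown here, with 4-chlorophenyl in place of methyl, a number 19 percentage points higher from compound 3 to compound 4 (beyond the scatter) in this assay, so a third aromatic ring on this carbon gives a higher number than methyl, and methyl remains the only group here with a clear step down from all three rings. What is new is that the ring's substituent can matter, although the first two rings looked alike: chloro in place of bromo on an aromatic carbon gives a number 13 percentage points lower from compound 2 to compound 4 (beyond the scatter), whereas 4-chlorophenyl in place of 3-chlorophenyl gives a number 9 percentage points lower from compound 1 to compound 4 (within the scatter). No measurement shown offers a reason for either difference.

Still open, on these data alone, is how an unsubstituted phenyl, a longer chain or an amine on this carbon would read. Also open, as far as these compounds go, is whether any group here can give a number below that of compound 3.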